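A few compounds are considered here, and "the series" means these few. Any claim that something is new, unique, unknown or untested is made for them only; others in the source may bear on it.

Of the compounds shown here, two measured so far share a common core and differ on both sides of it. Compound 1, `COc1cc(NC(=O)Nc2cc(Nc3ccc(C)c(C)c3)ncn2)cc(OC)c1`, carries a 3,4-dimethylphenyl group on a nitrogen on an aromatic ring. In a functional assay on HCC827 cells (Homo sapiens) for inhibition, read by MTT assay, with a stated time of 48 h, tested at 10 uM (on this read-out higher numbers stand for more inhibition at the one concentration tested (going by the name of the read-out) and lower numbers for less inhibition), compound 1 gives 45.7%. Going by the values given here, compound 2, `COc1ccc(Br)cc1Nc1cc(NC(=O)Nc2c(Cl)cccc2Cl)ncn1`, is the only other compound with a number; in this assay compound 2 gives 53%. These two numbers lie within the usual scatter of one another, so on the numbers shown compound 1 cannot be set apart from compound 2 in either direction.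

Compound 3, `COc1cc(NC(=O)Nc2cc(Nc3cc(I)ccc3OC)ncn2)cc(OC)c1`, has not yet been measured. It differs from compound 1 in one place: 5-iodo-2-methoxyphenyl in place of 3,4-dimethylphenyl on a nitrogen on an aromatic ring. Among the compounds with values here, compound 2 differs from compound 1 in more than one place, so no single step between measured compounds isolates this change, and the two values shown give no direction to lean on.

The step from compound 1 to compound 3 in this assay is therefore expected to be small, a number 4.3 percentage points higher from compound 1 to compound 3 (within the scatter), with no direction beyond the scatter. Compound 3 is thus estimated at 50%, within a range from 30% to 70%.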

Compound 3, a percentage reported as inhibition, at one concentration (the size of the read-out at that concentration, not a potency): 71%
Compound 3: the middle estimate sits 21 percentage points below what was measured; the whole stated range lies below it.
By their numbers in this assay, from the lowest: compounds 1 and 2 (each within the scatter of the next); then compound 3.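

In this assay, putting 5-iodo-2-methoxyphenyl in place of 3,4-dimethylphenyl on a nitrogen on an aromatic ring gives a number 25.3 percentage points higher from compound 1 to compound 3 (beyond the scatter), the first change in one place among these compounds and one whose size clears the usual variation between repeat measurements. This shows that the group at this position can shift the inhibition seen at the one concentration tested while the rest of the molecule stays the same, something the earlier pair could not show, since those two compounds differ in more than one place. Nothing shown here explains what about the entering group produces this step.

The change removes two methyl groups and adds an iodine and a methoxy group in a single move, so these compounds leave open whether the iodine, the methoxy group or only the two together account for the step. Also open, going by these compounds, is how this read-out would respond to a different group at the same nitrogen, such as a cyclohexyl ring or a phenyl ring carrying an amine or a carboxylic acid.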